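A few compounds are considered here, and "the series" means these few. Any claim that something is new, unique, unknown or untested is made for them only; others in the source may bear on it.

Measured compounds:
compound 1, `NS(=O)(=O)Oc1ccc2c(c1)CN(C(=O)c1ccc(N3CCCCC3)cc1)CC2` — in an assay on HEK293 cells for inhibition of Steryl-sulfatase (Homo sapiens), tested at 1 uM (on this read-out higher numbers stand for a stronger effect at the one concentration tested and lower numbers for a weaker effect), compound 1 gives 38.3%
compound 2, `NS(=O)(=O)Oc1ccc2c(c1)CN(C(=O)c1cccc(N(Cc3ccccc3)Cc3ccco3)c1)CC2` — in this assay compound 2 gives 90.5%

Compound 1 holds the lower of the two numbers in this assay; compound 2 stands higher by a gap beyond the scatter. The two compounds differ in more than one place, so their values are noted side by side without a counted step between them.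

Compound 3, `CCN(Cc1ccccc1)c1ccc(C(=O)N2CCc3ccc(OS(N)(=O)=O)cc3C2)cc1`, is not yet measured. Against compound 1 it carries benzyl(ethyl)amino in place of piperidin-1-yl on an aromatic carbon on the shared core. Going by the values given here, no measured pair isolates this change. Among the compounds with values here, the expectation for compound 3 in this assay is a step upward from compound 1, of a size clearly beyond the scatter, since compound 2, the only other number available, shows 90.5% with an open-chain benzyl-bearing amino group rather than a piperidin-1-yl. The estimated step is a number 31.7 percentage points higher from compound 1 to compound 3 (beyond the scatter). Compound 3 is estimated at 70%, with a range from 45% to 90%.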

Compound 3, a percentage reported as inhibition, at one concentration (the size of the read-out at that concentration, not a potency): 83.6%
Compound 3: middle estimate off by 13.6 percentage points, on the low side; low and high end bracket the measured number.
By their numbers in this assay, from the lowest: compound 1; then compounds 3 and 2 (each within the scatter of the next).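

In this assay, going by these compounds alone, benzyl(ethyl)amino in place of piperidin-1-yl on an aromatic carbon, para to a large group, gives a number 45.3 percentage points higher from compound 1 to compound 3 (beyond the scatter) and is the first single-place step, showing that the read-out at this position depends strongly on the group it carries. The entering group brings an aromatic ring of carbon only and 10 heavy atoms against 6, while the counts of hydrogen-bond donors and acceptors and the net charge stay the same. No measurement at hand accounts for the step.

The compounds shown do not separate the contribution of the benzyl from that of the ethyl, or of the open chain from that of the ring. On these data alone, whether dimethylamino or morpholin-4-yl at this position would read like compound 1 or like compound 3 remains open.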